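Trading pyridin-2-yl for a larger amine on compound 3

This account rests on a few compounds, and the source may have more. Where it says the series, first, only, none or still open, it means among the compounds named here.

Compound 3 `COc1ccc2[nH]c(C(=O)N3CC(=O)N(Cc4ccccc4)[C@@H](Cc4ccccn4)C3)cc2c1` has been tested in an ADME assay on Vero cells (Chlorocebus sabaeus) for cytotoxicity, with a stated time of 7 days; on this read-out lower numbers stand for higher toxicity in this test and higher numbers for lower toxicity in this test. In this assay compound 3 gives > 30000 nM, which is a limit of the assay rather than a number. Compound 1 `COc1cccc(CN2C(=O)CN(C(=O)c3cc4cc(OC)ccc4[nH]3)C[C@@H]2CCc2ccccc2)c1` gives 4500 nM. Compound 2 `COc1cccc(CN2C(=O)CN(C(=O)c3cc4cc(OC)ccc4[nH]3)C[C@@H]2Cc2ccccn2)c1` gives > 10000 nM, also a limit. The step of an at least 2.2-fold higher number from compound 1 to compound 2 (0.34 log units; beyond the scatter) touches the same saturated chain carbon that now changes again. The other step, a step that the two limits leave unreadable from compound 2 to compound 3, leaves the comparison open. Compound 4 `COc1ccc2[nH]c(C(=O)N3CC(=O)N(Cc4ccccc4)[C@@H](CN4CCC5(CCCC5)CC4)C3)cc2c1` differs from compound 3 by a group of 10 heavy atoms (9 carbon, 1 nitrogen; one five-membered non-aromatic ring of carbon only, one six-membered non-aromatic ring with 1 hetero atom) in place of a group of 6 heavy atoms (5 carbon, 1 nitrogen; one six-membered aromatic ring with 1 hetero atom), on a saturated chain carbon bound to a saturated ring carbon. Going by the values given here, no measured step covers this exchange, and compound 3 sits at the limit of > 30000 nM in this assay, at which 1 of the 3 values shown sits, so direction and size remain uncertain. The estimated step is an at least 1.5-fold lower number from compound 3 to compound 4 (0.17 log units; that floor lies within the scatter). Compound 4 is estimated at 20000 nM, between 5000 nM and 60000 nM.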

Compound 4, half-maximal cytotoxic concentration: 3600 nM
For compound 4 the middle estimate is 5.6-fold (0.74 log units) above the measured one; the whole stated range lies above it.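

In this assay, replacing pyridin-2-yl with the group of 10 heavy atoms gives an at least 8.3-fold lower number from compound 3 to compound 4 (0.92 log units; beyond the scatter). Earlier, the only readable change on this saturated chain carbon raised the number, so this is the first change there shown to lower it. The step is only a floor, because compound 3 stands at a limit: the limit of > 30000 nM in this assay, at which 1 of the 4 values shown sits.

The compounds shown leave open whether the six-membered non-aromatic ring alone carries this drop or the five-membered ring is also needed. A plain piperidin-1-yl on the same carbon would separate the two.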